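Series notes: from compound 2 toward compound 4

This account rests on a few compounds, and the source may have more. Where it says the series, first, only, none or still open, it means among the compounds named here.

Among the measured compounds shown here, the series so far comprises compound 1 `Cc1ccsc1/C=C(/SCc1ccc(Cl)c(Cl)c1)C(=O)c1ccc(Cl)cc1`, compound 2 `Cc1ccc(S/C(=C/c2sccc2C)C(=O)c2ccc(Cl)cc2)cc1` and compound 3 `Cc1ccsc1/C=C(/SCc1ccccc1F)C(=O)c1ccc(Cl)cc1`, all sharing one core and differing only in the group on the sulfur. In a functional assay on DU-145 cells (Homo sapiens) for inhibition, read by trypan blue exclusion, with a stated time of 96 h (a higher number here means a weaker inhibitor of growth, a lower number a stronger inhibitor of growth), compound 1 gives 50000 nM, compound 2 gives 50000 nM and compound 3 gives 50000 nM. Compound 2 therefore stands level with compounds 1 and 3 at the digits shown; the steps of no change at the digits printed from compound 1 to compound 2 (within the scatter), no change at the digits printed from compound 1 to compound 3 (within the scatter) and no change at the digits printed from compound 2 to compound 3 (within the scatter) are all within the scatter, so nothing in this assay separates the three.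

Compound 4 `COc1ccccc1/C=C(/Sc1ccc(C)cc1)C(=O)c1ccc(Cl)cc1` has not been measured. It departs from compound 2 at a different place than any measured step: 2-methoxyphenyl in place of 3-methylthiophen-2-yl on a double-bonded chain carbon bound to a double-bonded chain carbon. The three measured steps all concern the group on the sulfur and show no change; none touches the double-bonded chain carbon, so they do not bear directly on this change. Absent any step at that position, the working expectation is a step of no change at the digits printed from compound 2 to compound 4 (within the scatter) of no change beyond the scatter.

Compound 4 is accordingly estimated at 50000 nM in this assay, within a range from 20000 nM to 100000 nM.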

Compound 4, concentration for 50% growth inhibition: 25000 nM
Beside the measured number, compound 4's estimate is 2.0-fold (0.30 log units) above it, and the stated range covers the measured number.
By their numbers in this assay, from the lowest: compounds 4, 1, 2 and 3 (each within the scatter of the next).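

Among the compounds shown here, with 2-methoxyphenyl in place of 3-methylthiophen-2-yl on a double-bonded chain carbon bound to a double-bonded chain carbon, this assay gives a 2.0-fold lower number from compound 2 to compound 4 (0.30 log units; within the scatter) as the first reading at this position, one that the steps on the sulfur could not supply. In this one pair, a five-membered aromatic ring with 1 hetero atom and 6 heavy atoms gives way to a six-membered aromatic ring of carbon only with 8 heavy atoms, and the read-out does not separate the two compounds. No supporting data bear on this result.

From the compounds shown here alone, one replacement is a thin basis for judging this position, so it remains open whether a phenyl ring carrying a carboxylic acid or a dimethylamino group would move the number beyond the scatter. Also open, going by these compounds, is whether the same exchange reads alike with 3,4-dichlorobenzyl or 2-fluorobenzyl on the sulfur, and what a replacement for the 4-chlorophenyl group on the carbonyl, shared by all four compounds, would do.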